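The source may report more compounds than this note shows. Statements on the series, on what has been measured and on what is new or still open speak of the compounds shown alone.

Compound 1 `CCN(CC)c1ccc(N2C(=O)NC3(CSC4=C3C(=O)c3ncccc3C4=O)C2=O)cc1` gives 30 nM in a functional assay on MCF7 cells (Homo sapiens) for antiproliferative activity, read by MTT assay, with a stated time of 96 h (a higher number here means a weaker inhibitor, a lower number a stronger inhibitor), the second highest of the three numbers in hand. Compound 2 `CCc1ccc(N2C(=O)NC3(CSC4=C3C(=O)c3ncccc3C4=O)C2=O)cc1` gives 50 nM and compound 3 `Cc1ccc(N2C(=O)NC3(CSC4=C3C(=O)c3ncccc3C4=O)C2=O)cc1` gives 2 nM. The step from compound 1 to compound 4 `CC(C)(C)c1ccc(N2C(=O)NC3(CSC4=C3C(=O)c3ncccc3C4=O)C2=O)cc1` is tert-butyl in place of diethylamino on an aromatic carbon. Two measured steps leave the same diethylamino group: a 1.7-fold higher number from compound 1 to compound 2 (0.22 log units; within the scatter), whereas a 15-fold lower number from compound 1 to compound 3 (1.18 log units; beyond the scatter); between the two alkyl compounds, a 25-fold lower number from compound 2 to compound 3 (1.40 log units; beyond the scatter). The outcome thus depends on which alkyl group enters. Compound 4 carries an alkyl group of more than one carbon, as compound 2 does, and since a 1.7-fold higher number from compound 1 to compound 2 (0.22 log units; within the scatter) stayed within the scatter, no step beyond the scatter is expected for a 1.2-fold higher number from compound 1 to compound 4 (0.07 log units; within the scatter). Compound 4 is therefore expected to give about 35 nM, within a range of 8 nM to 150 nM.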

Compound 4, half-maximal inhibitory concentration: 130 nM
Compound 4: the middle estimate sits 3.7-fold (0.57 log units) below what was measured; the range from low to high includes it.
By their numbers in this assay, from the lowest: compound 3; then compounds 1 and 2 (each within the scatter of the next); then compound 4.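

In this assay tert-butyl does not stand in for diethylamino at this position, with a 4.3-fold higher number from compound 1 to compound 4 (0.64 log units; beyond the scatter) and so a step beyond the scatter where ethyl gave none. Among the alkyl groups on this aromatic carbon, the number rises from methyl through ethyl to tert-butyl, with a 65-fold higher number from compound 3 to compound 4 (1.81 log units; beyond the scatter) and a 2.6-fold higher number from compound 2 to compound 4 (0.41 log units; beyond the scatter) as the two steps that compound 4 adds, a trend resting on these three compounds alone. No measured evidence accounts for this order.

On these data alone, whether isopropyl or a propyl chain falls nearer methyl or tert-butyl remains open. So does whether dimethylamino, methoxy or chlorine in this place would match methyl.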